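From 2-hydroxyethyl to 2-methoxyethyl in compound 1

The source may report more compounds than this note shows. Statements on the series, on what has been measured and on what is new or still open speak of the compounds shown alone.

Of the compounds shown here, three with a shared core have been measured in an in vitro ADME assay on microsomes from liver (Homo sapiens) for metabolic stability; a higher number here means faster removal of the compound, a lower number slower removal. Compound 1 `Cc1cc(Nc2ccc(C(F)(F)F)cc2)n2nc(CCO)nc2n1`, which carries a 2-hydroxyethyl group, gives < 5 mL.min-1.g-1. That result is a limit of the assay and not a number. Compound 2 `Cc1cc(Nc2ccc(S(F)(F)(F)(F)F)cc2)n2nc(C3CC3)nc2n1` gives < 5 mL.min-1.g-1, which is also a limit. Compound 3 `Cc1cc(Nc2cccc(Cl)c2)n2nc(C(C)(F)F)nc2n1` gives a true number, 44.4 mL.min-1.g-1. From the compounds shown here alone, compound 1 therefore stands at the limit of < 5 mL.min-1.g-1 in this assay, at which 2 of the 3 values shown sit, and its exact value remains unknown.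

Compound 4 `COCCc1nc2nc(C)cc(Nc3ccc(C(F)(F)F)cc3)n2n1` is compound 1 with one change: methyl in place of hydrogen on an oxygen on a saturated carbon, which turns hydroxy to methoxy (methyl in place of hydrogen on an oxygen on a saturated carbon). Among the measured compounds shown here, no two measured compounds differ in only one place, so the data give no direct measure of what such a change does in this assay. The expectation here is therefore cautious: a small move towards faster removal, or none beyond the scatter. Compound 1 reads < 5 mL.min-1.g-1, a limit, so an upward move is the only kind that could be seen clearly. The expected size is an at least 1.4-fold higher number from compound 1 to compound 4 (0.14 log units; that floor lies within the scatter), and this is only an estimate. For compound 4 the estimated value is 7 mL.min-1.g-1, with an expected range from 3 mL.min-1.g-1 to 20 mL.min-1.g-1.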

Compound 4, intrinsic clearance in microsomes: 9 mL.min-1.g-1
For compound 4 the middle estimate is 1.3-fold (0.11 log units) below the measured one; measured number inside the range.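

Placing a methyl on the oxygen of the 2-hydroxyethyl group gives an at least 1.8-fold higher number from compound 1 to compound 4 (0.25 log units; that floor lies within the scatter) in this assay and provides the first direct comparison of two compounds that differ in one place. Compound 4 also gives a true number, so this side chain now has a measured value from which later changes could be compared, whereas compound 1 gives only a limit of the assay. The step can be stated only as a floor, and the true difference may be larger, because one end of the comparison is not a number: the limit of < 5 mL.min-1.g-1 in this assay, at which 2 of the 4 values shown sit.

With a floor inside the usual scatter, this single pair does not settle how large the effect of the change is, or whether it exceeds the normal variation between repeated measurements. The compounds shown leave open how a 2-aminoethyl group, a carboxylic acid or a longer chain such as 3-methoxypropyl would read at this place, and whether the same swap from hydroxy to methoxy gives a similar step when the trifluoromethyl group is replaced by another group.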